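Chain Extension on a Sulfonamide Nitrogen Toward 5-HT7 Binding

The source may report more compounds than this note shows. Statements on the series, on what has been measured and on what is new or still open speak of the compounds shown alone.

The series rests on a shared core, seen in compound 1 `O=S(=O)(NCCCN1CCc2ccccc2C1)c1ccccc1`, which in an assay on HEK293 cells for displacement of a labelled ligand from 5-hydroxytryptamine receptor 7 (Homo sapiens), read by scintillation counting, with a stated time of 1 h (on this read-out lower numbers stand for stronger inhibition and higher numbers for weaker inhibition), gives 270 nM. Compound 2 `NCCN(CCCN1CCc2ccccc2C1)S(=O)(=O)c1ccccc1` carries a 2-aminoethyl group on the sulfonamide nitrogen in place of hydrogen, and in this assay compound 2 gives 267 nM. The step of a 1.0-fold lower number from compound 1 to compound 2 (0.00 log units; within the scatter) shows that the added 2-aminoethyl chain left the inhibition constant unchanged within the scatter, so compound 2 stands beside compound 1 with no separation between them.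

Compound 3 `NCCCN(CCCN1CCc2ccccc2C1)S(=O)(=O)c1ccccc1` differs from compound 2 by a single change: aminomethyl in place of amino on a saturated chain carbon, two bonds along the chain from a sulfonamide nitrogen. For the measured compounds named here, the only measured step that bears on this change is the one from compound 1 to compound 2, in which introducing the amino-bearing chain produced no shift beyond the scatter. Lengthening that same chain by one carbon is a smaller alteration than introducing it, and on this evidence no step beyond the scatter is expected in this assay, in either direction.

The estimate for compound 3 is therefore 270 nM, with a range from 120 nM to 600 nM, corresponding to an expected step of a 1.0-fold higher number from compound 2 to compound 3 (0.00 log units; within the scatter).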

Compound 3, inhibition constant: 335 nM
The estimate for compound 3 lay 1.2-fold (0.09 log units) below the measured number; the measured number falls inside the stated range.
By their numbers in this assay, from the lowest: compounds 2, 1 and 3 (each within the scatter of the next).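

In this assay, the step of a 1.3-fold higher number from compound 2 to compound 3 (0.10 log units; within the scatter) shows that this one-carbon extension, aminomethyl in place of amino on a saturated chain carbon, two bonds along the chain from a sulfonamide nitrogen, does not separate the two compounds. The step of a 1.2-fold higher number from compound 1 to compound 3 (0.09 log units; within the scatter) adds a second chain length to the earlier 2-aminoethyl result, so both 2-aminoethyl and 3-aminopropyl on this nitrogen now lie within the scatter of the hydrogen in compound 1, and the terminal amino group can sit on either chain with no measurable difference in this read-out. No measurement on hand accounts for this lack of separation.

The compounds shown leave open whether a longer chain, such as 4-aminobutyl, would also stay within the scatter of compound 1, and whether the terminal amine matters at all, which a plain propyl or a 3-hydroxypropyl chain on the same nitrogen would test. They also leave open what a dimethylamino group or a carboxylic acid at the end of the chain would do to the inhibition constant.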